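This account rests on a few compounds, and the source may have more. Where it says the series, first, only, none or still open, it means among the compounds named here.

In an ADME assay on NHDF cells (Homo sapiens) for cytotoxicity, read by MTT assay, with a stated time of 72 h (on this read-out higher numbers stand for weaker inhibition and lower numbers for stronger inhibition), compound 1 (`COc1ccccc1/C=C1\CCC/C(=C\c2ccc(OC)c(OC)c2)C1=O`) gives 18100 nM, compound 2 (`COc1cccc(/C=C2\CCC/C(=C\c3ccc(OC)c(OC)c3)C2=O)c1`) gives 11600 nM and compound 3 (`COc1ccc(/C=C2\CCC/C(=C\c3cc(Cl)cc(Cl)c3)C2=O)cc1OC`) gives 8300 nM on the same read-out. Compound 3 cannot be separated from compound 2 (a 1.4-fold lower number from compound 2 to compound 3 (0.15 log units; within the scatter)) and parts from compound 1 only modestly (a 2.2-fold lower number from compound 1 to compound 3 (0.34 log units; beyond the scatter)). Compound 4 (`COc1ccc(/C=C2\CCC/C(=C\c3ccc(O)c(Cl)c3)C2=O)cc1OC`) has 3-chloro-4-hydroxyphenyl in place of 3,5-dichlorophenyl (3-chloro-4-hydroxyphenyl in place of 3,5-dichlorophenyl on a double-bonded chain carbon bound to a double-bonded ring carbon). Among the compounds with values here, the remaining swap at this place is also small (a 1.6-fold lower number from compound 1 to compound 2 (0.19 log units; within the scatter)), and no measured compound carries a hydroxy group, so no step beyond the scatter is expected in this assay in either direction. The estimated step is small (a 1.1-fold higher number from compound 3 to compound 4 (0.04 log units; within the scatter)). Compound 4 is expected at 9000 nM within a range of 4000 nM to 20000 nM for now.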

Compound 4, half-maximal inhibitory concentration: 21900 nM
The estimate for compound 4 lay 2.4-fold (0.39 log units) below the measured number, outside the stated range (above it).
By their numbers in this assay, from the lowest: compounds 3, 2, 1 and 4 (each within the scatter of the next, the first and the last beyond it).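

Within the data shown here, on a double-bonded chain carbon bound to a double-bonded ring carbon, 3-chloro-4-hydroxyphenyl gives the first swap with a hydroxy group in this assay, and it goes beyond the scatter only modestly against 3,5-dichlorophenyl (a 2.6-fold higher number from compound 3 to compound 4 (0.42 log units; beyond the scatter)). The same group stays within the scatter against both methoxyphenyl compounds (a 1.9-fold higher number from compound 2 to compound 4 (0.28 log units; within the scatter)) and (a 1.2-fold higher number from compound 1 to compound 4 (0.08 log units; within the scatter)). No available evidence accounts for the step.

On these data alone, whether the hydroxy group or the lost chlorine carries the step stays open. So does the outcome with an amine or a carboxylic acid on this phenyl.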